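Iodo for Methoxy on the Anilino Ring

This account rests on a few compounds, and the source may have more. Where it says the series, first, only, none or still open, it means among the compounds named here.

Measured compounds:
compound 1 `COc1ccc(NC2=CC(=O)c3c(nc4n3[C@H]3OC[C@@H](O)[C@H]3OC4)C2=O)cc1` gives 4470 nM in a functional assay on MCF7 cells (Homo sapiens) for inhibition, read by sulforhodamine B assay; on this read-out lower numbers stand for stronger inhibition and higher numbers for weaker inhibition
compound 2 `O=C1C=C(Nc2cccc(Cl)c2)C(=O)c2c1nc1n2[C@H]2OC[C@@H](O)[C@H]2OC1` gives 4720 nM in this assay
compound 3 `COc1ccc(NC2=CC(=O)c3nc4n(c3C2=O)[C@H]2OC[C@@H](O)[C@H]2OC4)cc1` gives 5420 nM in this assay

All three share the same core and differ only in the aryl group on the amine nitrogen. Compound 1 has the lowest number of the three, but its gaps to compound 2 and to compound 3 both fall within the scatter, so the three numbers cannot be told apart. For the measured compounds named here, the one step between measured compounds, a 1.1-fold higher number from compound 2 to compound 3 (0.06 log units; within the scatter), swaps one aryl group for another and also stays within the scatter.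

Compound 4 `O=C1C(Nc2ccc(I)cc2)=CC(=O)c2c1nc1n2[C@H]2OC[C@@H](O)[C@H]2OC1` differs from compound 1 as follows: iodo in place of methoxy on an aromatic carbon. Going by the values given here, no measured step changes this substituent, so the only guidance is that the aryl swap from compound 2 to compound 3 left the number unchanged. The same is therefore expected here in this assay: an expected step of a 1.0-fold higher number from compound 1 to compound 4 (0.00 log units; within the scatter), with no change beyond the scatter. Compound 4 is expected to give 4500 nM, within 1500 nM to 13500 nM.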

Compound 4, half-maximal inhibitory concentration: 3890 nM
Compound 4: middle estimate off by 1.2-fold (0.06 log units), on the high side, and the stated range covers the measured number.
By their numbers in this assay, from the lowest: compounds 4, 1, 2 and 3 (each within the scatter of the next).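

In this assay, the change of methoxy to iodo gives a 1.1-fold lower number from compound 1 to compound 4 (0.06 log units; within the scatter). Unlike the earlier swap of one whole aryl group for another, this step alters a single substituent on an aromatic carbon, para to a large group, while the rest of the 4-methoxyphenyl group stays in place. Methoxy, with two heavy atoms and a hydrogen-bond acceptor, and iodo, with one heavy atom and no acceptor, thus cannot be told apart here, and nothing available explains this. The compounds shown leave open whether the number would stay within the scatter with an amine or a carboxylic acid at this same place. They also leave open whether a plain hydrogen there would read alike, and whether iodo would behave the same way elsewhere on the ring.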